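The compounds below may be only part of what the source reports. "The series", "measured", "known", "first", "only" and "open" are said of these compounds alone.

Measured so far in a functional assay on HL-60 cells (Homo sapiens) for cytotoxicity, read by MTT assay, with a stated time of 48 h; on this read-out higher numbers stand for weaker inhibition and lower numbers for stronger inhibition:
compound 1 `COc1ccccc1Nc1nc(-c2cccc(F)c2)nc2ccc(F)cc12`, a limit only, > 50000 nM.
compound 2 `Fc1ccc(Nc2nc(-c3cccc(F)c3)nc3ccc(F)cc23)cc1`, a limit only, > 50000 nM.
compound 3 `Fc1cccc(-c2nc(Nc3ccc(Br)cc3)c3cc(F)ccc3n2)c1`, a limit only, > 50000 nM.

Compound 2 stands at a limit in this assay, and the two other values in the series are limits as well, as the limit of > 50000 nM in this assay, at which 3 of the 3 values shown sit, records. No ordering of the three can be read from these numbers; each sits at the same limit.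

The compound to be measured is compound 4 `Oc1cccc(Nc2nc(-c3cccc(F)c3)nc3ccc(F)cc23)c1`. Its difference from compound 2: 3-hydroxyphenyl in place of 4-fluorophenyl on a nitrogen on an aromatic ring.

The measured steps that bear on this exchange are those touching the same nitrogen substituent, a step that the two limits leave unreadable from compound 1 to compound 2 and a step that the two limits leave unreadable from compound 1 to compound 3, together with the exchange on the aromatic carbon, a step that the two limits leave unreadable from compound 2 to compound 3. All three run from one limit to another, so their size is not readable. Nothing among them shows any swap of this phenyl moving a compound off the limit in this assay.

The step from compound 2 to compound 4 is therefore expected to be a number no higher from compound 2 to compound 4 (the limit leaves the size open), that is, nothing readable. Compound 4 is estimated at 50000 nM, within 15000 nM to 150000 nM, most probably reported again as a limit in this assay.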

Compound 4, half-maximal inhibitory concentration: > 50000 nM
Compound 4: only a limit was reported; the forecaster's own chance of this, stated with the estimate: 80%; the middle value sits exactly at the limit.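

Compound 4 gives no readable step to compound 1, compound 2 or compound 3 in this assay, since all four values are limits and not numbers: the limit of > 50000 nM in this assay, at which 4 of the 4 values shown sit.

The compounds shown leave open how these four rank against one another, and whether any group on this nitrogen gives a measurable value in this assay.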